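A few compounds are considered here, and "the series" means these few. Any claim that something is new, unique, unknown or untested is made for them only; others in the source may bear on it.

Compound 2 `CC(O)c1ccc(C(=O)N[C@@H](C)Cn2ccc(-c3ccc(C#N)c(Cl)c3)n2)cc1` shares its core with compound 1 `CC(O)c1cccc(C(=O)N[C@@H](C)Cn2ccc(-c3ccc(C#N)c(Cl)c3)n2)c1`, the two differing only in where the 1-hydroxyethyl group sits on the phenyl ring. In an ADME assay on PC-3 cells (Homo sapiens) for cytotoxicity, read by CCK-8 assay, with a stated time of 6 days (on this read-out lower numbers stand for stronger inhibition and higher numbers for weaker inhibition), compound 1 reaches only the limit of > 30000 nM. In this assay compound 2 likewise reaches only the limit of > 30000 nM. Within the data shown here, the step that the two limits leave unreadable from compound 1 to compound 2 therefore cannot be read, and the sole evidence is the limit of > 30000 nM in this assay, at which 2 of the 2 values shown sit. Compound 3 `COc1ccc(C(=O)N[C@@H](C)Cn2ccc(-c3ccc(C#N)c(Cl)c3)n2)cc1` carries methoxy in place of 1-hydroxyethyl on an aromatic carbon. Among the measured compounds shown here, no measured step with a readable size bears on this change, so nothing beyond the scatter is expected in this assay. Compound 3 is expected to give about 40000 nM, between 15000 nM and 200000 nM, a step that the limit leaves unreadable from compound 2 to compound 3.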

Compound 3, half-maximal inhibitory concentration: > 30000 nM
Compound 3 ended at the assay's limit (the forecaster's own chance of this, stated with the estimate: 85%); the middle value lies beyond the limit too.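

In this assay compound 3 gives > 30000 nM, which is a limit. The steps to compound 3 from compound 1 and from compound 2 therefore cannot be read. The compounds shown leave open how large any of these changes is, and which change to the shared core would give a value within the limit.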